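Phenyl in place of furan-3-yl on the shared core

A few compounds are considered here, and "the series" means these few. Any claim that something is new, unique, unknown or untested is made for them only; others in the source may bear on it.

Three compounds carry readings so far. Compound 1 `CNc1ncnc2c1c(-c1cc3ccccc3o1)cn2[C@@H]1O[C@H](CO)[C@@H](O)[C@H]1O` gives > 20000 nM in a functional assay on CEM-DNR-bulk cells (Homo sapiens), read by MTT assay, with a stated time of 72 h (a lower number here means a stronger inhibitor, a higher number a weaker inhibitor), and this is a limit of the assay, not a number. In this assay compound 2 `C#Cc1cn([C@@H]2O[C@H](CO)[C@@H](O)[C@H]2O)c2nc(C)nc(N)c12` gives 12600 nM and compound 3 `Nc1nc2c(c(-c3ccoc3)cn2[C@@H]2O[C@H](CO)[C@@H](O)[C@H]2O)c(=O)[nH]1` gives 15000 nM. Those two values lie within the usual scatter of each other, so compound 3 stands level with compound 2, and no numerical comparison with compound 1 is possible.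

The next compound is compound 4 `Nc1nc2c(c(-c3ccccc3)cn2[C@@H]2O[C@H](CO)[C@@H](O)[C@H]2O)c(=O)[nH]1`, which has phenyl in place of furan-3-yl on an aromatic carbon. The group sits on a five-membered aromatic ring with 1 nitrogen, two ring bonds from the ring nitrogen. Going by the values given here, no measured pair differs in one place, so the size of this change has no direct precedent here. The expectation therefore starts from compound 3 at 15000 nM, with no step beyond the scatter foreseen in this assay. The expected change, a 1.2-fold higher number from compound 3 to compound 4 (0.08 log units; within the scatter), is estimated to stay within that scatter. Compound 4 may also be reported only as a limit. For compound 4 the estimated value is 18000 nM, with an expected range of 9000 nM to 30000 nM.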

Compound 4, half-maximal inhibitory concentration: > 20000 nM
Compound 4: only a limit was reported; the forecaster's own chance of this, stated with the estimate: 45%; middle value at least 1.1-fold (0.04 log units) away from the limit.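

In this assay, going by these compounds alone, phenyl in place of furan-3-yl on an aromatic carbon of the five-membered aromatic ring with 1 nitrogen gives an at least 1.3-fold higher number from compound 3 to compound 4 (0.12 log units; that floor lies within the scatter), the first step between compounds that differ in one place. Compound 4 gives > 20000 nM, which is a limit of the assay and not a number, and it shares that limit with compound 1: the limit of > 20000 nM in this assay, at which 2 of the 4 values shown sit.

The step therefore fixes only a floor, and as that floor lies within the scatter, the data do not separate phenyl from furan-3-yl at this position. From the compounds shown here alone, how far compound 4 actually lies from compound 3 stays unknown. Also open is whether any other group on this aromatic carbon, such as an amine, a carboxylic acid or a longer alkyl chain, would give a clearly lower number on the shared core, since the compounds shown offer only these two aromatic rings for comparison there.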